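This account rests on a few compounds, and the source may have more. Where it says the series, first, only, none or still open, it means among the compounds named here.

Measured so far in a functional assay on BXPC-3 cells (Homo sapiens) for antiproliferative activity, read by MTT assay, with a stated time of 24 h; a lower number here means a stronger inhibitor, a higher number a weaker inhibitor:
Compound 1 `CCn1c(C(=O)NC(C)(C)CO)ccc1C(CC)(CC)c1ccc(OCS(=O)(=O)c2ccccc2)c(C)c1`: 18300 nM
Compound 2 `CCn1c(C(=O)NC2(C(=O)O)CC2)ccc1C(CC)(CC)c1ccc(OCS(=O)(=O)c2ccccc2)c(C)c1`: > 50000 nM (a limit, not a number)

Compound 2 stands at the limit of > 50000 nM in this assay, at which 1 of the 2 values shown sits. Compound 3 `CCn1c(C(=O)NCCC(=O)O)ccc1C(CC)(CC)c1ccc(OCS(=O)(=O)c2ccccc2)c(C)c1` differs from compound 2 by 2-carboxyethyl in place of 1-carboxycyclopropyl on an amide-type nitrogen, with 2-carboxyethyl in place of 1-carboxycyclopropyl on the amide-type nitrogen. Among the compounds with values here, the one measured step at this nitrogen is an at least 2.7-fold higher number from compound 1 to compound 2 (0.43 log units; beyond the scatter), and it rests on a limit. Compound 3 keeps a carboxy group on an open chain, so no change beyond the scatter is expected in this assay, in either direction, given the result for compound 2 of > 50000 nM. The expected step is a number no higher from compound 2 to compound 3 (the limit leaves the size open). The estimate for compound 3 is 50000 nM, with an expected range from 22000 nM to 100000 nM.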

Compound 3, half-maximal inhibitory concentration: > 50000 nM
Compound 3 ended at the assay's limit (the forecaster's own chance of this, stated with the estimate: 60%); the middle value sits exactly at the limit.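

In this assay, 2-carboxyethyl in place of 1-(hydroxymethyl)-1-methylethyl on the amide-type nitrogen gives an at least 2.7-fold higher number from compound 1 to compound 3 (0.43 log units; beyond the scatter), so this loss is now seen with a carboxy-bearing group both with and without the three-membered ring. The step between the two carboxy compounds cannot be read, since both values are limits: the limit of > 50000 nM in this assay, at which 2 of the 3 values shown sit.

The compounds shown leave open how far either carboxy compound lies past that limit. They also leave open whether a methyl ester or an amine at the end of the chain on this nitrogen would give a readable number.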